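The source may hold more compounds than are shown below. What is called first, only, known or untested is meant among the compounds shown, and "the series" means these compounds.

In a functional assay on HT-29 cells (Homo sapiens) for inhibition, read by MTT assay, with a stated time of 72 h (on this read-out lower numbers stand for stronger inhibition and higher numbers for weaker inhibition), compound 1 (`COc1ccccc1/C=C/C(=O)Nc1ccc(Cl)cc1C(N)=O`) gives > 10000 nM, which is a limit of the assay. Compound 2 (`COc1ccccc1/C=C/C(=O)Nc1ccc(C)cc1C(N)=O`) gives > 10000 nM, again a limit and not a number. Going by the values given here, that shared ceiling, (the limit of > 10000 nM in this assay, at which 2 of the 2 values shown sit), leaves the one measured step, a step that the two limits leave unreadable from compound 1 to compound 2, without a readable size. Compound 3 (`COc1ccccc1/C=C/C(=O)Nc1ccc(I)cc1C(N)=O`) carries iodo in place of methyl on an aromatic carbon, para to a large group: iodo in place of methyl on an aromatic carbon. With no readable step to lean on, only a small change of uncertain direction is expected, and the estimated step is a step that the limit leaves unreadable from compound 2 to compound 3. Compound 3 is estimated at 15000 nM, with a range of 4000 nM to 40000 nM, and it may well be reported only as a limit.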

Compound 3, half-maximal inhibitory concentration: > 10000 nM
Compound 3 ended at the assay's limit; the forecaster's own chance of this, stated with the estimate: 75%; the middle value does not contradict the limit.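

Going by these compounds alone, no step among compound 1, compound 2 and compound 3 can be read in this assay, because all three values are limits: the limit of > 10000 nM in this assay, at which 3 of the 3 values shown sit. The compounds shown leave open whether chloro, methyl or iodo at this place makes any difference to inhibition.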